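Methoxy to trifluoromethyl on the aromatic ring

This account rests on a few compounds, and the source may have more. Where it says the series, first, only, none or still open, it means among the compounds named here.

Compound 2 `COc1ccc(SC)c(NCC2=NCCN2)c1` gives 603 nM in an assay on CHO cells for binding affinity to Alpha-2C adrenergic receptor (Homo sapiens), read by radioligand binding (on this read-out higher numbers stand for weaker inhibition and lower numbers for stronger inhibition), and stands at the higher end of the two measured numbers; its nearest neighbour is compound 1 `CSc1ccc(C)cc1NCC1=NCCN1`, which in this assay gives 200 nM. Compound 3 `CSc1ccc(C(F)(F)F)cc1NCC1=NCCN1` carries trifluoromethyl in place of methoxy on an aromatic carbon. For the measured compounds named here, the only measured step that bears on this position is the exchange of methyl for methoxy, which gave a 3.0-fold higher number from compound 1 to compound 2 (0.48 log units; beyond the scatter), so a single small substituent change at this place shifted the number only modestly. Going by the values given here, no measured step shows trifluoromethyl itself, and a shift of similar size in either direction is plausible. Among the compounds with values here, with the modest outcome of the step from compound 1 to compound 2 as the only guide, compound 3 is expected to land near the two measured values, with an estimated step of a 1.5-fold lower number from compound 2 to compound 3 (0.18 log units; within the scatter) in this assay. Compound 3 is therefore estimated at 400 nM, within a range from 150 nM to 1200 nM.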

Compound 3, inhibition constant: 603 nM
Beside the measured number, compound 3's estimate is 1.5-fold (0.18 log units) below it; the range from low to high includes it.
By their numbers in this assay, from the lowest: compound 1; then compounds 2 and 3 (each within the scatter of the next).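

In this assay the exchange of methoxy for trifluoromethyl, on the aromatic carbon para to a methylsulfanyl group, leaves the reading unmoved (no change at the digits printed from compound 2 to compound 3 (within the scatter)). The earlier compounds showed only that methoxy stood apart from methyl; now a second group with more heavy atoms and no hydrogen-bond acceptor stands apart from methyl by the same measure (a 3.0-fold higher number from compound 1 to compound 3 (0.48 log units; beyond the scatter)), so among these three compounds, methyl gives the strongest inhibition. Nothing at hand accounts for methoxy and trifluoromethyl reading alike or for methyl differing from both.

What the compounds shown leave open is how an amine, a carboxylic acid or a longer alkyl chain would read at this place. They also leave open whether any group there would give a lower number than methyl.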